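Dropping the amino group from a purine core

This account rests on a few compounds, and the source may have more. Where it says the series, first, only, none or still open, it means among the compounds named here.

Four compounds share a closely related core carrying a chloromethyl-substituted benzyl group, and differ in the small groups on the six-membered aromatic ring. Compound 1 `ClCc1cccc(Cn2cnc3c(Cl)nc(Cl)nc32)c1` carries two chloro groups, compound 3 `ClCc1ccc(Cn2cnc3ncnc(Cl)c32)cc1` carries a single chloro group with the benzyl attached in a different pattern, and compound 2 `Nc1nc(Cl)c2ncn(Cc3cccc(CCl)c3)c2n1` carries a chloro group and an amino group. In a functional assay on RXF 393 cells (Homo sapiens) for cytotoxicity, read by sulforhodamine B assay, with a stated time of 48 h (a higher number here means that more compound is tolerated, a lower number that less compound is tolerated), compound 1 gives 5120 nM, and compound 3 gives 12000 nM. For compound 2 the entry in this assay reads "not determined" (no result reported), so its standing among the measured compounds cannot be stated.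

Compound 4 `ClCc1cccc(Cn2cnc3c(Cl)ncnc32)c1` is reached from compound 2 by a change in one place: hydrogen in place of amino on an aromatic carbon. Going by the values given here, with no value for compound 2 and no pair of measured compounds showing this exact change, the size and direction of the step in this assay cannot be anchored from the numbers themselves, and only the two measured neighbours, compound 1 and compound 3, give a sense of where compound 4 is likely to land. Compound 4 is expected to give about 8000 nM, with a likely range from 3000 nM to 25000 nM.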

Compound 4, concentration lethal to 50% of the cells: 70800 nM
Compound 4: the middle estimate sits 8.9-fold (0.95 log units) below what was measured; measured number above the stated range.
By their numbers in this assay, from the lowest: compound 1; then compound 3; then compound 4.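

In this assay the aromatic carbon between two ring nitrogen atoms turns out to matter: putting hydrogen in place of chloro there gives a 14-fold higher number from compound 1 to compound 4 (1.14 log units; beyond the scatter) and so marks a large step, with far more compound tolerated once the chloro group has gone. Going by these compounds alone, this is the first pair of measured compounds here that differ in one place, and the change falls on the same carbon that carries the amino group in compound 2, so what sits on this carbon clearly can shift the result. No measurement at hand explains why the loss of this chloro group has such an effect.

From the compounds shown here alone, the step from compound 2 to compound 4 cannot be read, so it remains unknown whether an amino group on this carbon behaves more like chloro or more like hydrogen. Also open, going by these compounds, is where a methyl or a methoxy group on this carbon would fall in this assay on the shared core, and whether the size of this step would hold with the chloromethyl group placed differently on the benzyl ring.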